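Notes on the aryl ether side chain, compound 2 to compound 3

The source may report more compounds than this note shows. Statements on the series, on what has been measured and on what is new or still open speak of the compounds shown alone.

Measured so far:
compound 1 `CCN(CC)C(=O)COc1ccc(C[C@H]2C(=O)OC[C@@H]2Cc2ccc(OC)c(OC)c2)cc1OC`: 188000 nM
compound 2 `COc1ccc(C[C@H]2COC(=O)[C@@H]2Cc2ccc(OCC(=O)N3CCOCC3)c(OC)c2)cc1OC`: >= 600000 nM, a limit of the assay

Compound 1 in an ADME assay on HeLa cells (Homo sapiens) for cytotoxicity, read by MTT assay (a lower number here means a stronger inhibitor, a higher number a weaker inhibitor), gives 188000 nM. Compound 2 gives >= 600000 nM in this assay, which is a limit of the assay and not a number. Of the two values shown, compound 2 therefore stands at the upper end, on (the limit of >= 600000 nM in this assay, at which 1 of the 2 values shown sits). Among the compounds with values here, the only measured step is an at least 3.1-fold higher number from compound 1 to compound 2 (0.50 log units; beyond the scatter), where the amide nitrogen substituent changes while the carbonyl is kept.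

Compound 3 `COc1ccc(C[C@H]2COC(=O)[C@@H]2Cc2ccc(OCc3cn(-c4ccc(C)cc4)nn3)c(OC)c2)cc1OC` is not yet measured. The change from compound 2 is 1-(4-methylphenyl)-1H-1,2,3-triazol-4-yl in place of (morpholin-4-yl)carbonyl on a saturated chain carbon bound to an oxygen on an aromatic ring. No measured step covers a change of this kind: the one step shown swaps one amine on the carbonyl for another, whereas here the carbonyl itself leaves and an aromatic system enters on the chain carbon. The measured step therefore gives only weak guidance, and the starting point is a limit. Compound 3 is expected to give about 300000 nM in this assay, with a range from 80000 nM to 1000000 nM. This estimate means an at least 2.0-fold lower number from compound 2 to compound 3 (0.30 log units; that floor lies within the scatter), with a fair chance that only a limit is again reported.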

Compound 3, half-maximal inhibitory concentration: >= 600000 nM
Compound 3 ended at the assay's limit; the forecaster's own chance of this, stated with the estimate: 45%; middle value at least 2.0-fold (0.30 log units) away from the limit.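

In this assay compound 3 gives >= 600000 nM, which is a limit of the assay and not a number. On the saturated chain carbon bound to an oxygen on an aromatic ring, the carbonyl is therefore not needed to reach this limit: replacing diethylcarbamoyl with 1-(4-methylphenyl)-1H-1,2,3-triazol-4-yl gives an at least 3.1-fold higher number from compound 1 to compound 3 (0.50 log units; beyond the scatter), so a second, structurally unrelated group also moves the series away from compound 1. The step between compound 2 and compound 3 cannot be read, because both values are limits: the limit of >= 600000 nM in this assay, at which 2 of the 3 values shown sit.

From the compounds shown here alone, compound 1 is the only one of the three with a number rather than a limit, so the order of compound 2 and compound 3 stays open, as does how the (morpholin-4-yl)carbonyl and 1-(4-methylphenyl)-1H-1,2,3-triazol-4-yl groups compare in this assay. Going by these compounds, it is also open whether a carboxylic acid or a primary amine on the same chain carbon would give a number in this assay, and how that number would stand against compound 1.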